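From 4-methylpiperazin-1-yl to 4-acetylpiperazin-1-yl

This account rests on a few compounds, and the source may have more. Where it says the series, first, only, none or still open, it means among the compounds named here.

In a physicochemical assay for solubility, using the shake flask method, measured as kinetic solubility, with a stated time of 2 h, at pH 7.4 (a higher number here means a more soluble compound, a lower number a less soluble compound), compound 1 (`CN(Cc1ccc(C(F)(F)F)nc1)c1cc(C(=O)Nc2ccccc2)ncn1`) gives < 5000 nM, which is a limit. Going by the values given here, compound 2 (`CN1CCN(c2ccc(NC(=O)c3cc(N(C)Cc4ccc(C(F)(F)F)nc4)ncn3)cc2)CC1`) gives 165000 nM, the only actual number so far. Compound 3 (`CC(=O)N1CCN(c2ccc(NC(=O)c3cc(N(C)Cc4ccc(C(F)(F)F)nc4)ncn3)cc2)CC1`) has acetyl in place of methyl on an amine nitrogen in a ring. Among the compounds with values here, one measured step bears on this: an at least 33-fold higher number from compound 1 to compound 2 (1.51 log units; beyond the scatter), a large one, which brought in the 4-methylpiperazin-1-yl group now being altered. Part of that gain is expected to be lost, with an expected step of a 5.5-fold lower number from compound 2 to compound 3 (0.74 log units; beyond the scatter) in this assay. The estimate for compound 3 is 30000 nM, with an expected range of 8000 nM to 100000 nM.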

Compound 3, solubility: < 5000 nM
Compound 3: only a limit was reported (the forecaster's own chance of this, stated with the estimate: 15%); at least 6.0-fold (0.77 log units) between middle value and limit.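

In this assay, acetyl in place of methyl on the amine nitrogen in the ring gives an at least 33-fold lower number from compound 2 to compound 3 (1.51 log units; beyond the scatter). Among these compounds, keeping the six-membered ring does not keep the higher number: the group on this nitrogen decides the read-out. The size of the step rests on a limit rather than on two numbers: the limit of < 5000 nM in this assay, at which 2 of the 3 values shown sit.

The step from compound 1 to compound 3 cannot be read, as both values are limits. Open, on these data alone, is how this nitrogen behaves with an ethyl group, a longer chain ending in an amine, or a chain ending in a carboxylic acid.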